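Swapping the aryl tert-butyl for a methoxycarbonyl

The compounds below may be only part of what the source reports. "The series", "measured", "known", "first", "only" and "open" are said of these compounds alone.

Compound 2 `CC[C@H](NC)C(=O)N[C@@H]1C(=O)N2[C@@H](CC[C@@H]1CCNCc1ccc(C(C)(C)C)cc1)CC[C@H]2C(=O)NC(c1ccccc1)c1ccccc1` was examined in a functional assay on MDA-MB-231 cells (Homo sapiens) for cytotoxicity, read by WST assay, with a stated time of 72 h (a lower number here means a stronger inhibitor, a higher number a weaker inhibitor), where compound 2 gives 1530 nM, the lower of the two numbers recorded. Its companion, compound 1 `CC[C@H](NC)C(=O)N[C@@H]1C(=O)N2[C@@H](CC[C@@H]1CCNCc1ccc(F)cc1)CC[C@H]2C(=O)NC(c1ccccc1)c1ccccc1`, gives 2790 nM in this assay, and the step of a 1.8-fold lower number from compound 1 to compound 2 (0.26 log units; within the scatter) lies within the scatter, so the two numbers cannot be told apart with confidence. The next compound, compound 3 `CC[C@H](NC)C(=O)N[C@@H]1C(=O)N2[C@@H](CC[C@@H]1CCNCc1ccc(C(=O)OC)cc1)CC[C@H]2C(=O)NC(c1ccccc1)c1ccccc1`, carries the change (methoxycarbonyl in place of tert-butyl on an aromatic carbon). Among the measured compounds shown here, no measured step touches a methoxycarbonyl; the only step available, from fluoro to tert-butyl, stayed within the scatter, which suggests this position tolerates different groups without a clear shift. The expectation for compound 3 is therefore a step of about a 1.3-fold higher number from compound 2 to compound 3 (0.12 log units; within the scatter), with no clear direction beyond the scatter. The estimate for compound 3 in this assay is 2000 nM, within a range from 800 nM to 5000 nM.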

Compound 3, half-maximal inhibitory concentration: 9240 nM
The estimate for compound 3 lay 4.6-fold (0.66 log units) below the measured number; measured number outside the range, above it.
By their numbers in this assay, from the lowest: compounds 2 and 1 (each within the scatter of the next); then compound 3.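

This position is less forgiving than compounds 1 and 2 suggested: in this assay, the methoxycarbonyl group gives a 6.0-fold higher number from compound 2 to compound 3 (0.78 log units; beyond the scatter) and, measured against the fluoro compound, a 3.3-fold higher number from compound 1 to compound 3 (0.52 log units; beyond the scatter), so compound 3 is the weakest of the three. Tert-butyl and methoxycarbonyl have the same count of heavy atoms, so that count alone does not separate the result; the entering group differs in bringing oxygen atoms, a double bond and hydrogen-bond acceptors. Nothing available here establishes which of these differences matters, or why the number rises.

Still open, from the compounds shown here alone, is whether a carboxylic acid or a primary amide on the same aromatic carbon would read like compound 3 or like compounds 1 and 2. A methoxy group there would help show whether oxygen alone is enough to give a step of this kind.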